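This account rests on a few compounds, and the source may have more. Where it says the series, first, only, none or still open, it means among the compounds named here.

Of the compounds shown here, three built on one shared core have been tested in a functional assay on the whole organism (strain albino) for inhibition, with Rattus norvegicus as the target, read by paw edema, with stated times of 1 h and 3 h, at a dose of 20 mmol/kg by the intraperitoneal route; on this read-out higher numbers stand for a stronger effect at the one dose given and lower numbers for a weaker effect. Compound 1 `N#CC1=C(/N=C/Nc2ccc([N+](=O)[O-])cc2)N(c2ccccc2)C(=O)N2CCCCC(N3CCCC3)C12` gives 85.6% in this assay. Compound 2 `CCOC(=O)C(=O)NC1=C(C#N)C2C(N3CCCC3)CCCCN2C(=O)N1c1ccccc1` gives 91.5% in this assay, and compound 3 `N#CC1=C(/N=C/Nc2ccccc2)N(c2ccccc2)C(=O)N2CCCCC(N3CCCC3)C12` gives 79.3% in this assay, the lowest of the three numbers. Its nearest neighbour is compound 1, with a number 6.3 percentage points lower from compound 1 to compound 3 (within the scatter), while the step of a number 12.2 percentage points lower from compound 2 to compound 3 (beyond the scatter) lies beyond the scatter.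

Compound 4 `N#CC1=C(N)N(c2ccccc2)C(=O)N2CCCCC(N3CCCC3)C12` differs from compound 3 by one nitrogen atom in place of a group of 9 heavy atoms (7 carbon, 2 nitrogen; one six-membered aromatic ring of carbon only), on a double-bonded ring carbon. Two measured steps change the same double-bonded ring carbon: a number 5.9 percentage points higher from compound 1 to compound 2 (within the scatter) and a number 12.2 percentage points lower from compound 2 to compound 3 (beyond the scatter). For the measured compounds named here, neither involves an amino group, so the direction for compound 4 is not fixed by the data; the one step beyond the scatter went with a bulkier group giving the lower number, and the other change at that carbon stayed within the scatter. Compound 4 is therefore expected to land near compound 3, with a number 0.7 percentage points higher from compound 3 to compound 4 (within the scatter) expected in this assay. Compound 4 is estimated at 80% in this assay, within a range of 64% to 92%.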

Compound 4, a percentage reported as inhibition, in the whole organism at one dose (the size of the read-out at that dose, not a potency): 90.1%
Estimate against measurement, compound 4: 10.1 percentage points below, and the stated range covers the measured number.
By their numbers in this assay, from the lowest: compounds 3, 1, 4 and 2 (each within the scatter of the next, the first and the last beyond it).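

With a number 10.8 percentage points higher from compound 3 to compound 4 (beyond the scatter), the result shows that in this assay the amino group alone on this double-bonded ring carbon reads clearly apart from the group of 9 heavy atoms in compound 3, so the larger group with its aromatic ring is not required at this position for a high number. For the compounds shown here, the other two steps stay within the scatter, a number 1.4 percentage points lower from compound 2 to compound 4 (within the scatter) for hydrogen in place of (ethoxycarbonyl)carbonyl on the amine nitrogen and a number 4.5 percentage points higher from compound 1 to compound 4 (within the scatter) for the amino group in place of the nitro-bearing group, so among the groups at this position only that of compound 3 stands apart from compound 4. Nothing shown here accounts for these differences.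

On these data alone, it remains open how a methyl or an acetyl on the amine nitrogen would read in this assay. As far as these compounds go, it is equally open whether a hydroxyl in place of the amino group would keep the number of compound 4.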